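A Mirror-Image Change and Its Expected Solubility

A few compounds are considered here, and "the series" means these few. Any claim that something is new, unique, unknown or untested is made for them only; others in the source may bear on it.

Three compounds have been measured in a physicochemical assay for solubility, read by HPLC, in phosphate buffer, measured as thermodynamic solubility, with a stated time of 24 h, at pH 6.8; on this read-out higher numbers stand for higher solubility and lower numbers for lower solubility:

compound 1 `C=CC(=O)N1CCC[C@@H](N2C(=O)N(Cc3ccccc3)Cc3cnc(Nc4ccc(N5CCN(C)CC5)cc4OC)nc32)C1` gives 142 ug/mL
compound 2 `C=CC(=O)N1CC[C@H](N2C(=O)N(C3CCCCC3)Cc3cnc(Nc4ccc(N5CCN(C)CC5)cc4OC)nc32)C1` gives 763 ug/mL
compound 3 `C=CC(=O)N1CC[C@H](N2C(=O)N(c3ccccc3)Cc3cnc(Nc4cccc(N5CCN(C)CC5)c4)nc32)C1` gives 714 ug/mL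

Among these three, compound 1 stands lowest; compound 3 sits a step above it that lies beyond the usual scatter, and compound 2 sits a little further still. Compound 4 `C=CC(=O)N1CCC[C@H](N2C(=O)N(Cc3ccccc3)Cc3cnc(Nc4ccc(N5CCN(C)CC5)cc4OC)nc32)C1` has not been measured. Its relation to compound 1 is simple: the two compounds have the same atoms and bonds and differ only in configuration as drawn: 1 of 1 stereo elements differ; a stereocentre at a saturated ring carbon is drawn R in compound 1 and S in compound 4. Every atom and bond stays the same; only the handedness at that one ring carbon is mirrored. Within the data shown here, no measured pair here shows what such a mirror change does to solubility, so the expectation rests on the change itself. A step of none beyond the scatter is expected, and no change at the digits printed from compound 1 to compound 4 (within the scatter) expresses that. Compound 4 is therefore estimated at 142 ug/mL in this assay, with a range from 70 ug/mL to 290 ug/mL.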

Compound 4, solubility: 129 ug/mL
Compound 4: middle estimate off by 1.1-fold (0.04 log units), on the high side; the range from low to high includes it.
By their numbers in this assay, from the lowest: compounds 4 and 1 (each within the scatter of the next); then compounds 3 and 2 (each within the scatter of the next).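

In this assay, mirroring this one ring carbon gives a 1.1-fold lower number from compound 1 to compound 4 (0.04 log units; within the scatter), the first direct reading of such a change among these compounds. In this pair, the handedness at that carbon leaves solubility within the usual scatter. The comparison is clean, with no other structural change to account for the numbers: the fact that compounds 1 and 4 differ only in the configuration as drawn

On these data alone, whether handedness at this carbon matters as little when the shared core carries a carboxylic acid remains open. A single mirror-image pair also cannot show whether the result holds for other pairs.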